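The source may report more compounds than this note shows. Statements on the series, on what has been measured and on what is new or still open speak of the compounds shown alone.

Measured so far:
compound 1 `Cc1ccc(CNC(=O)c2nc(-c3ccc(F)cc3)n(CC[C@@H](O)C[C@@H](O)CC(=O)O)c2C2CC2)cc1`, giving 1.7 nM in an assay on microsomes from liver for inhibition of 3-hydroxy-3-methylglutaryl-coenzyme A reductase (Rattus norvegicus), read by scintillation counting, with stated times of 0.5 h and 0.75 h; a higher number here means a weaker inhibitor, a lower number a stronger inhibitor
compound 2 `Cc1cccc(CNC(=O)c2nc(-c3ccc(F)cc3)n(CC[C@@H](O)C[C@@H](O)CC(=O)O)c2C2CC2)c1`, giving 7.2 nM in this assay

The two compounds share one core and differ only in the methylphenyl group attached to the saturated chain carbon bound to the amide-type nitrogen. For the measured compounds named here, compound 2 holds the higher of the two numbers and is thus the weaker inhibitor of the pair; the single measured step, a 4.2-fold higher number from compound 1 to compound 2 (0.63 log units; beyond the scatter), shows how much moving the methyl group on that ring changed the result.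

Compound 3 `COc1ccccc1CNC(=O)c1nc(-c2ccc(F)cc2)n(CC[C@@H](O)C[C@@H](O)CC(=O)O)c1C1CC1` has not yet been measured. It differs from compound 2 in one place: 2-methoxyphenyl in place of 3-methylphenyl on a saturated chain carbon bound to an amide-type nitrogen. The measured step bears on this only loosely: a 4.2-fold higher number from compound 1 to compound 2 (0.63 log units; beyond the scatter) shows that shifting a small group around that ring can move the number by a modest amount, but neither a methoxy group nor its placement here has been tested. A modest step in either direction, or none beyond the scatter, remains plausible.

Compound 3 is expected to land near 5 nM, within 1.5 nM to 20 nM. That corresponds to an expected step of a 1.4-fold lower number from compound 2 to compound 3 (0.16 log units; within the scatter).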

Compound 3, half-maximal inhibitory concentration in the 3-hydroxy-3-methylglutaryl-coenzyme A reductase assay: 7 nM
Compound 3: the middle estimate sits 1.4-fold (0.15 log units) below what was measured, and the stated range covers the measured number.
By their numbers in the 3-hydroxy-3-methylglutaryl-coenzyme A reductase assay, from the lowest: compound 1; then compounds 3 and 2 (each within the scatter of the next).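

In the 3-hydroxy-3-methylglutaryl-coenzyme A reductase assay, putting 2-methoxyphenyl in place of 3-methylphenyl gives a 1.0-fold lower number from compound 2 to compound 3 (0.01 log units; within the scatter), so this position, on a saturated chain carbon bound to an amide-type nitrogen, takes a ring carrying an oxygen and a hydrogen-bond acceptor with no readable change in the result. Set against the 4-methylphenyl group, the same 2-methoxyphenyl group gives a 4.1-fold higher number from compound 1 to compound 3 (0.61 log units; beyond the scatter), which leaves compound 1 apart from the other two, whose different ring substituents give matching numbers. The exchange is not silent, though: in a physicochemical assay for lipophilicity, using the shake flask method, at pH 7.4 (a lower number here means a more polar compound, a higher number a more lipophilic compound), compound 2 gives 0.47 and compound 3 gives 0.16, so compound 3 is the more polar of the pair, and polarity shifted while the inhibition number held: the measured distribution coefficient of compound 2, 0.47, and of compound 3, 0.16, a number 0.31 log units lower (beyond the scatter)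

What the compounds shown leave open is whether the methoxy group itself or its place on the ring matters more, as the step from 3-methylphenyl to 2-methoxyphenyl changes both at once, and a 4-methoxyphenyl group would speak to that. Going by these compounds, how a ring bearing an amine or a carboxylic acid would fare at this position also remains open.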